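Furan to Cyclopropyl on a Shared Core

The source may report more compounds than this note shows. Statements on the series, on what has been measured and on what is new or still open speak of the compounds shown alone.

Compound 1 `O=C(O)c1cccc(Cc2c(-c3ccco3)nn3cc(Cl)ccc23)n1` gives 1200 nM in a functional assay on cells for antagonist activity at prostaglandin E2 receptor EP1 subtype (Rattus norvegicus), read by fluorescence and calcium flux, with a stated time of 60 s; a higher number here means a weaker inhibitor, a lower number a stronger inhibitor.
Compound 2 `O=C(O)c1cccc(Cc2c(-c3ccoc3)nn3cc(Cl)ccc23)n1` gives 130 nM in this assay.

Among the compounds with values here, compound 2 stands with the lower of the two numbers measured so far; its nearest neighbour is compound 1, and the step of a 9.2-fold lower number from compound 1 to compound 2 (0.97 log units; beyond the scatter) sets them apart beyond the usual scatter. Compound 3 `O=C(O)c1cccc(Cc2c(C3CC3)nn3cc(Cl)ccc23)n1` differs from compound 2 by cyclopropyl in place of furan-3-yl on an aromatic carbon.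

Within the data shown here, only one measured step is available, and it exchanges one furan isomer for another at this same position. It bears on the new change only indirectly: it shows that the group at this position matters, since even a 9.2-fold lower number from compound 1 to compound 2 (0.97 log units; beyond the scatter) followed a small rearrangement within the furan. The change to compound 3 is larger, removing the furan ring entirely and putting a smaller, non-aromatic ring in its place, so a noticeable shift in this assay is expected, with the direction uncertain and a weaker inhibitor somewhat more likely. Compound 3 is therefore estimated at 450 nM, with a range from 80 nM to 2500 nM, corresponding to the expected step of a 3.5-fold higher number from compound 2 to compound 3 (0.54 log units; beyond the scatter).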

Compound 3, half-maximal inhibitory concentration: 1500 nM
Beside the measured number, compound 3's estimate is 3.3-fold (0.52 log units) below it, within the range that was stated.
By their numbers in this assay, from the lowest: compound 2; then compounds 1 and 3 (each within the scatter of the next).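

Putting cyclopropyl in place of furan-3-yl gives a 12-fold higher number from compound 2 to compound 3 (1.06 log units; beyond the scatter) in this assay, so the lower number of compound 2 does not carry over to this smaller, non-aromatic ring of carbon only. Within the data shown here, the other comparison, a 1.3-fold higher number from compound 1 to compound 3 (0.10 log units; within the scatter), shows that compound 1 and compound 3 cannot be told apart, which leaves furan-3-yl as the only one of the three groups with a clearly lower number; having a ring at this position is therefore not enough on its own, and the furan oxygen has to sit in the right place within an aromatic ring or some other feature of furan-3-yl must count. Nothing measured on these compounds explains why furan-3-yl differs from the other two groups.

Cyclopropyl differs from furan-3-yl in ring size, aromatic character and the oxygen all at once, so the compounds shown cannot separate these changes from one another. They also leave open how the position would respond to a group of a different kind, such as an amine, a methoxy group or a longer carbon chain.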